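Removing a Ring Hydroxy: Compound 2 to Compound 3

This account rests on a few compounds, and the source may have more. Where it says the series, first, only, none or still open, it means among the compounds named here.

compound 1, `COc1cc(/C=C/C(=O)OC[C@H](Cc2ccc(O)c(OC)c2)[C@H](CO)Cc2ccc(O)c(OC)c2)ccc1O`: 18.9 ug/mL
compound 2, `C=C[C@@]1(C)COC(=O)C1(O)C(=O)/C=C(\O)c1ccccc1`: 62.1 ug/mL

In a functional assay on MCF7 cells (Homo sapiens) for cytotoxicity, read by MTT assay, with a stated time of 48 h (a lower number here means a stronger inhibitor, a higher number a weaker inhibitor), compound 2 gives 62.1 ug/mL, the highest of the two numbers, and compound 1 gives 18.9 ug/mL, a lower number beyond the usual scatter. Compound 3, `C=C[C@@]1(C)COC(=O)C1C(=O)/C=C(\O)c1ccccc1`, is not yet measured. It differs from compound 2 by hydrogen in place of hydroxy on a saturated ring carbon. For the measured compounds named here, no measured pair in this set shows a comparable change, so no direction can be read from the data, and the step from compound 2 to compound 3 is expected to lie within the scatter, at a 1.1-fold lower number from compound 2 to compound 3 (0.05 log units; within the scatter). Compound 3 is therefore estimated at 55 ug/mL, between 22 ug/mL and 140 ug/mL.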

Compound 3, half-maximal inhibitory concentration: 52.9 ug/mL
Compound 3: middle estimate off by 1.0-fold (0.02 log units), on the high side; the measured number falls inside the stated range.
By their numbers in this assay, from the lowest: compound 1; then compounds 3 and 2 (each within the scatter of the next).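

In this assay, for the compounds shown here, the only comparison in this set between compounds that differ in one place gives a 1.2-fold lower number from compound 2 to compound 3 (0.07 log units; within the scatter). Compound 2 and compound 3 therefore cannot be told apart, so the hydroxy on this saturated ring carbon, two ring bonds from the ring oxygen, is not required for a reading at this level. On these data alone, whether an amine, a carboxylic acid or a longer chain on this same ring carbon would separate from compound 2 remains open. No available evidence bears on this result.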